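Removing the chloro from the anilide ring of compound 2

The source may hold more compounds than are shown below. What is called first, only, known or untested is meant among the compounds shown, and "the series" means these compounds.

Measured compounds:
compound 1 `C/C(=N\NC(=S)Nc1ccc(Cl)cc1)c1ccccn1`: 3.7 nM
compound 2 `C/C(=N\NC(=S)Nc1ccccc1Cl)c1ccccn1`: 1.4 nM

In a functional assay on RT2 cells (Rattus norvegicus) for cytotoxicity, read by MTT assay, with a stated time of 48 h (a higher number here means a weaker inhibitor, a lower number a stronger inhibitor), compound 2 gives 1.4 nM, the lowest of the two numbers; the nearest is compound 1 with 3.7 nM, a gap beyond the scatter. Compound 3 `C/C(=N\NC(=S)Nc1ccccc1)c1ccccn1` differs from compound 2 by hydrogen in place of chloro on an aromatic carbon, ortho to a large group. Going by the values given here, no measured step of this kind exists, so the expectation rests on compound 2 alone. A modest rise in the number is expected, a 2.1-fold higher number from compound 2 to compound 3 (0.33 log units; beyond the scatter), possibly within the scatter. Compound 3 is therefore estimated at 3 nM, with a range from 1 nM to 10 nM.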

Compound 3, half-maximal inhibitory concentration: 1.4 nM
The estimate for compound 3 lay 2.1-fold (0.33 log units) above the measured number; the range from low to high includes it.
By their numbers in this assay, from the lowest: compounds 2 and 3 (each within the scatter of the next); then compound 1.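

In this assay hydrogen in place of chloro on an aromatic carbon, ortho to a large group, leaves the number where it was (no change at the digits printed from compound 2 to compound 3 (within the scatter)), so the low number at this position does not depend on the chloro. The same exchange at the chloro of the other chlorinated compound does register (a 2.6-fold lower number from compound 1 to compound 3 (0.42 log units; beyond the scatter)), so only that chloro stands apart from the unsubstituted ring. Nothing shown here accounts for either step. Still open, on these data alone, is what a methoxy group, a fluoro or an amine would do at this position.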